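Bromo to Isopropyl: Expecting Only a Modest Shift

The source may report more compounds than this note shows. Statements on the series, on what has been measured and on what is new or still open speak of the compounds shown alone.

Compound 1 `CNC(=O)c1ccccc1Oc1nc(Nc2cccc(Br)c2)ncc1Br` is the starting point. In a functional assay on A549 cells (Homo sapiens) for antiproliferative activity, read by MTT assay, with a stated time of 24 h (a higher number here means a weaker inhibitor, a lower number a stronger inhibitor), compound 1 gives 10600 nM, the second highest of the three numbers measured. Compound 2 `CNC(=O)c1ccccc1Oc1nc(Nc2cccc(C(F)(F)F)c2)ncc1Br` gives 28300 nM, and compound 3 `CNC(=O)c1ccccc1Oc1nc(Nc2cccc(OC)c2)ncc1Br` gives 6230 nM. Compound 4 `CNC(=O)c1ccccc1Oc1nc(Nc2cccc(C(C)C)c2)ncc1Br` differs from compound 1 by isopropyl in place of bromo on an aromatic carbon. Going by the values given here, two measured steps touch the same position: a 2.7-fold higher number from compound 1 to compound 2 (0.43 log units; beyond the scatter) and a 1.7-fold lower number from compound 1 to compound 3 (0.23 log units; within the scatter), so exchanging the bromo there has moved the number only modestly, in either direction. Among the compounds with values here, an isopropyl group has not been tried, so no measured step shows its effect directly. For compound 4 the expected step is a 1.1-fold lower number from compound 1 to compound 4 (0.03 log units; within the scatter), a change not beyond the scatter. Compound 4 is therefore estimated at 10000 nM, with a range from 4000 nM to 30000 nM.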

Compound 4, half-maximal inhibitory concentration: 7140 nM
For compound 4 the middle estimate is 1.4-fold (0.15 log units) above the measured one, within the range that was stated.
By their numbers in this assay, from the lowest: compounds 3, 4 and 1 (each within the scatter of the next); then compound 2.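

In this assay, the new isopropyl group falls in with bromo and methoxy: a 1.5-fold lower number from compound 1 to compound 4 (0.17 log units; within the scatter) and a 1.1-fold higher number from compound 3 to compound 4 (0.06 log units; within the scatter) both lie within the scatter, so compounds 1, 3 and 4 cannot be told apart, even though isopropyl is all carbon and larger than bromo by count of heavy atoms. Only compound 2 stands apart, with a 4.0-fold lower number from compound 2 to compound 4 (0.60 log units; beyond the scatter) beyond the scatter. Nothing available explains why trifluoromethyl alone separates from the other groups. Going by these compounds, whether an amine, a carboxylic acid or a longer chain at this position would stay with the close group or move as far as trifluoromethyl remains open.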